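Trading a Carboxamide Ring for a Plain Azepane

A few compounds are considered here, and "the series" means these few. Any claim that something is new, unique, unknown or untested is made for them only; others in the source may bear on it.

This short series shares one core, carried here by compound 1, whose structure is `Cc1nn([C@H](C)c2ccc(Cl)cc2Cl)c2nc(N3CC[C@H](N4CCC[C@H]4C(N)=O)[C@H](C)C3)cnc12`. In an assay on CCRF-CEM cells for antagonist activity at C-C chemokine receptor type 4 (Homo sapiens), read by CellTiter-Glo, with stated times of 30 min and 60 min, in the presence of a further agent that is not named here (on this read-out higher numbers stand for weaker inhibition and lower numbers for stronger inhibition), compound 1 gives "not determined" (no result reported), so it stands on no number of its own. Among the compounds with values here, the only measured member is compound 2, with structure `C[C@@H]1CC(c2cnc3c(C#N)nn([C@H](C)c4ccc(Cl)cc4Cl)c3n2)=CC[C@@H]1N1CCC[C@H]1C(C)(C)O`, which in this assay gives 1200 nM; it differs from compound 1 in several places at once, so it sets only a loose reference point.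

The step under study leads to compound 3, whose structure is `Cc1nn([C@H](C)c2ccc(Cl)cc2Cl)c2nc(N3CC[C@H](N4CCCCCC4)[C@H](C)C3)cnc12`. The change from compound 1 is azepan-1-yl in place of 2-carbamoylpyrrolidin-1-yl on a saturated ring carbon. The amide hydrogen-bond donor on the five-membered ring is lost, and a larger, purely carbon-and-nitrogen seven-membered ring takes its place.

Within the data shown here, with no value for compound 1 and no measured pair showing this exchange, the expected step cannot be anchored to data; a step within the usual scatter, or a modest loss, seems the most reasonable expectation. On that basis compound 3 is estimated at 1500 nM in this assay, within a range from 300 nM to 8000 nM.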

Compound 3, half-maximal inhibitory concentration: 195 nM
For compound 3 the middle estimate is 7.7-fold (0.89 log units) above the measured one; the whole stated range lies above it.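

In this assay, within the data shown here, compound 3 gives 195 nM but compound 1 gives "not determined" (no result reported), so no step between compound 1 and compound 3 can be read, and compound 2 differs from both in several places. No supporting data here explain the value of compound 3. The compounds shown leave open how far azepan-1-yl in place of 2-carbamoylpyrrolidin-1-yl changes inhibition.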